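Cytotoxicity limit in the step to compound 4

The source may hold more compounds than are shown below. What is called first, only, known or untested is meant among the compounds shown, and "the series" means these compounds.

compound 1 `FC(F)(F)c1ccc(-c2nn(-c3ccccc3)cc2CNc2ccc(Cl)cc2)cc1`: > 100000 nM
compound 2 `Brc1ccc(NCc2cn(-c3ccccc3)nc2-c2ccccc2)cc1`: > 100000 nM
compound 3 `Cc1ccc(-c2nn(-c3ccccc3)cc2CNc2ccc(Cl)cc2)cc1`: > 100000 nM

All three compounds were read in an ADME assay on MT4 cells (Homo sapiens) for cytotoxicity, read by MTT assay, with a stated time of 96 h (a lower number here means that less compound is tolerated, a higher number that more compound is tolerated), and none of them gave a number. Compound 3 stands at > 100000 nM, which is a limit. The set as a whole reads the limit of > 100000 nM in this assay, at which 3 of the 3 values shown sit, and offers no numerical value to work from.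

Compound 4 `Clc1ccc(NCc2cn(-c3ccccc3)nc2-c2ccccc2)cc1` follows from compound 3 by hydrogen in place of methyl on an aromatic carbon, that is, 4-methylphenyl to phenyl. Going by the values given here, the one measured step in that place is a step that the two limits leave unreadable from compound 1 to compound 3, so it gives no size. Compound 2 already carries phenyl in that place, and compound 2 gives > 100000 nM, also a limit.

No step beyond the scatter is therefore expected in this assay for this change. The expected size is a number no higher from compound 3 to compound 4 (the limit leaves the size open), and it cannot be read finely while the starting value is a limit. For compound 4 the estimate is 100000 nM, with an expected range of 50000 nM to 100000 nM, and a report of only a limit is the likeliest outcome.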

Compound 4, half-maximal cytotoxic concentration: > 100000 nM
Compound 4 ended at the assay's limit; the forecaster's own chance of this, stated with the estimate: 85%; the middle value sits exactly at the limit.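

In this assay, going by these compounds alone, compound 4 gives > 100000 nM as a limit, so no step among compound 1, compound 2, compound 3 and compound 4 can be read. The compounds shown leave open at what concentration cytotoxicity appears in this series, with no numerical value to place it: the limit of > 100000 nM in this assay, at which 4 of the 4 values shown sit.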